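The source may report more compounds than this note shows. Statements on the series, on what has been measured and on what is new or still open speak of the compounds shown alone.

Compound 2 `Cc1nc(C(F)(F)F)ccc1C(=O)Nc1ccc(Cl)c(-n2cccn2)c1` gives the highest of the two numbers recorded so far in an assay on C3H 10T1/2 cells for inhibition of Sonic hedgehog protein (Mus musculus), read by a luciferase reporter (a higher number here means a weaker inhibitor, a lower number a stronger inhibitor), with compound 2 at 450 nM. Among the compounds with values here, its nearest neighbour, compound 1 `Cc1nc(C(F)(F)F)ccc1C(=O)Nc1ccc(Cl)c(-n2cc3ccccc3n2)c1`, gives 80 nM in this assay, and the only measured step, a 5.6-fold higher number from compound 1 to compound 2 (0.75 log units; beyond the scatter), shows what happens when a bicyclic group is replaced by a monocyclic one at that carbon. Compound 3 `Cc1nc(C(F)(F)F)ccc1C(=O)Nc1ccc(Cl)c(-c2cnc3ccccc3n2)c1` reverses that direction of change: quinoxalin-2-yl in place of 1H-pyrazol-1-yl on an aromatic carbon. Since the step from compound 1 to compound 2 was modest but beyond the scatter, the return of a bicyclic group in compound 3 is expected to lower the number again, though the new group is joined through a carbon rather than a nitrogen, so the step is expected to be a 3.0-fold lower number from compound 2 to compound 3 (0.48 log units; beyond the scatter). On that basis compound 3 is estimated at 150 nM, within a range from 40 nM to 600 nM.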

Compound 3, half-maximal inhibitory concentration: 52 nM
Estimate against measurement, compound 3: 2.9-fold (0.46 log units) above; measured number inside the range.
By their numbers in this assay, from the lowest: compounds 3 and 1 (each within the scatter of the next); then compound 2.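

At this position, on an aromatic carbon ortho to a chloro group, quinoxalin-2-yl in place of 1H-pyrazol-1-yl gives an 8.7-fold lower number from compound 2 to compound 3 (0.94 log units; beyond the scatter) in this assay, so a second bicyclic group, joined through a carbon rather than a nitrogen, also stands apart from the monocyclic group. Quinoxalin-2-yl in place of 2H-indazol-2-yl gives a 1.5-fold lower number from compound 1 to compound 3 (0.19 log units; within the scatter), so this assay does not separate these two bicyclic groups, even though their joining atoms differ. No evidence is available to explain the difference from the 1H-pyrazol-1-yl group.

The compounds shown leave open whether the second ring itself matters, since a single ring joined through carbon, such as pyridin-2-yl, does not appear among them. Going by these compounds, it also remains open how the quinoxalin-2-yl group would respond to an added methoxy group or amine.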